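Adding an amino group to the pyridine ring of compound 1

This account rests on a few compounds, and the source may have more. Where it says the series, first, only, none or still open, it means among the compounds named here.

Compound 1, `C[C@@H](c1ccc(NC(=O)N2CC(c3cccnc3)C2)cc1)N1Cc2ccccc2C1=O`, is measured in a physicochemical assay for solubility, read by LC-MS, in phosphate buffer, with a stated time of 24 h, at pH 6.8 (on this read-out higher numbers stand for higher solubility and lower numbers for lower solubility), where compound 1 gives 130000 nM. Among the three measured compounds it stands second highest. Compound 2, `C[C@H](NC(=O)c1cccc(F)c1)c1ccc(NC(=O)N2CC(c3cccnc3)C2)cc1`, gives 11000 nM in this assay, a change described by a 12-fold lower number from compound 1 to compound 2 (1.07 log units; beyond the scatter). Compound 3, `C[C@H](NC(=O)C1CCOCC1)c1ccc(NC(=O)N2CC(c3cccnc3)C2)cc1`, gives 380000 nM, a change described by a 2.9-fold higher number from compound 1 to compound 3 (0.47 log units; beyond the scatter), and the two differ from each other by a 35-fold higher number from compound 2 to compound 3 (1.54 log units; beyond the scatter). All three of these steps alter the group on the saturated chain carbon, not the pyridine ring.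

Compound 4, `C[C@@H](c1ccc(NC(=O)N2CC(c3ccc(N)nc3)C2)cc1)N1Cc2ccccc2C1=O`, differs from compound 1 by amino in place of hydrogen on an aromatic carbon. Among the measured compounds shown here, no measured step touches this part of the shared core, so none of the three bears directly on the change, and the expectation rests only on the value of compound 1. The estimated step is a 1.2-fold higher number from compound 1 to compound 4 (0.06 log units; within the scatter), expected to remain within the usual scatter. Compound 4 is therefore expected to give about 150000 nM in this assay, with a range from 50000 nM to 450000 nM.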

Compound 4, solubility: 220000 nM
Compound 4: middle estimate off by 1.5-fold (0.17 log units), on the low side; low and high end bracket the measured number.
By their numbers in this assay, from the lowest: compound 2; then compounds 1, 4 and 3 (each within the scatter of the next, the first and the last beyond it).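

In this assay, amino in place of hydrogen, next to the ring nitrogen and para to a large group, gives a 1.7-fold higher number from compound 1 to compound 4 (0.23 log units; within the scatter). Among the compounds shown here, this is the first measured change on the pyridine ring, and it shows that this position can carry amino without a step beyond the usual scatter. The earlier steps shown here concerned only the group on the saturated chain carbon, and there the size of the step could be large, as in a 12-fold lower number from compound 1 to compound 2 (1.07 log units; beyond the scatter). Nothing measured here gives a reason for the result with amino.

On these data alone, it remains open whether a larger group at the same place, such as dimethylamino or methoxy, would also stay within the scatter. As far as these compounds go, it is equally open whether amino would behave the same way on compound 2 or compound 3.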